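The source may hold more compounds than are shown below. What is called first, only, known or untested is meant among the compounds shown, and "the series" means these compounds.

Measured compounds:
- compound 1 `COc1ccc(-n2cc(COc3cccc(NC(=O)Nc4ccc(Cl)c(C(F)(F)F)c4)c3)nn2)cc1` gives 4680 nM in a functional assay on HepG2 cells (Homo sapiens) for inhibition, read by MTT assay, with a stated time of 72 h; on this read-out lower numbers stand for stronger inhibition and higher numbers for weaker inhibition
- compound 2 `O=C(Nc1cccc(OCc2cn(-c3ccccc3F)nn2)c1)Nc1ccc(Cl)c(C(F)(F)F)c1` gives 1520 nM in this assay

Going by the values given here, compound 2 holds the lowest number of the two measured compounds; its nearest neighbour is compound 1, and the only measured step, a 3.1-fold lower number from compound 1 to compound 2 (0.49 log units; beyond the scatter), lies beyond the scatter. Compound 3 `O=C(Nc1cccc(OCc2cn(-c3cccc(C(F)(F)F)c3)nn2)c1)Nc1ccc(Cl)c(C(F)(F)F)c1` differs from compound 2 in one place: 3-(trifluoromethyl)phenyl in place of 2-fluorophenyl on an aromatic nitrogen. Among the compounds with values here, the one step that bears on this change is a 3.1-fold lower number from compound 1 to compound 2 (0.49 log units; beyond the scatter), since it also swaps the group on the same aromatic nitrogen; it shows that this position can move the number, but it gives no guide to the direction for a third group. He therefore expects compound 3 to land near compound 2, with a step of a 1.2-fold lower number from compound 2 to compound 3 (0.07 log units; within the scatter) that need not exceed the scatter. His estimate for compound 3 in this assay is 1300 nM, within a range from 450 nM to 4000 nM.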

Compound 3, half-maximal inhibitory concentration: 1270 nM
Compound 3: the middle estimate sits 1.0-fold (0.01 log units) above what was measured; low and high end bracket the measured number.
By their numbers in this assay, from the lowest: compounds 3 and 2 (each within the scatter of the next); then compound 1.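

In this assay, the exchange of 2-fluorophenyl for 3-(trifluoromethyl)phenyl, a 1.2-fold lower number from compound 2 to compound 3 (0.08 log units; within the scatter), leaves the two compounds indistinguishable, although the entering group has 10 heavy atoms against 7 for the group it replaces. The comparison with the 4-methoxyphenyl group, a 3.7-fold lower number from compound 1 to compound 3 (0.57 log units; beyond the scatter), lies beyond the scatter, as the earlier step to 2-fluorophenyl did, and both fluorine-bearing phenyl groups therefore stand apart from 4-methoxyphenyl on this aromatic nitrogen. Nothing available here gives a reason for these numbers.

The compounds shown leave open whether this nitrogen needs an aromatic ring at all, or whether a cyclohexyl group or a longer chain ending in an amine would give a similar number. They also leave open how a phenyl ring carrying a carboxylic acid would read in this assay at this position.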